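A few compounds are considered here, and "the series" means these few. Any claim that something is new, unique, unknown or untested is made for them only; others in the source may bear on it.

Measured so far:
compound 1, `CCOC(=O)C1=Cc2ccccc2OC1(OCc1cn(-c2ccc(F)cc2)nn1)C(F)(F)F`: 8900 nM
compound 2, `O=C(O)C1=Cc2ccccc2OC1(OCc1cc(-c2ccc([N+](=O)[O-])cc2)no1)C(F)(F)F`: 100000 nM

Of the compounds shown here, two have been measured in a functional assay on DU-145 cells (Homo sapiens) for inhibition, read by MTT assay, with a stated time of 24 h; on this read-out higher numbers stand for weaker inhibition and lower numbers for stronger inhibition. Compound 1 gives 8900 nM, the lower of the two numbers. Compound 2 gives 100000 nM in this assay, a higher number that lies beyond the usual scatter of such measurements. Compound 2 differs from compound 1 in more than one place, so its weaker result cannot be tied to any single change; only the two values themselves can be compared.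

Compound 3 is `CCOC(=O)C1=Cc2ccccc2OC1(OCc1cn(-c2ccc(F)c([N+](=O)[O-])c2)nn1)C(F)(F)F`. Relative to compound 1 it carries a single change: nitro in place of hydrogen on an aromatic carbon. Among the measured compounds shown here, no pair of measured compounds is joined by this change, so there is nothing in the data to show how it moves the read-out. Compound 2 also carries a nitro group, but on a different part of the molecule and together with other changes, so its value is not a guide here.

Given this, the step from compound 1 to compound 3 is estimated as small, a 1.2-fold higher number from compound 1 to compound 3 (0.09 log units; within the scatter), and not clearly beyond the scatter in either direction. Compound 3 is therefore expected to give about 11000 nM in this assay, within a range of 3500 nM to 40000 nM.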

Compound 3, half-maximal inhibitory concentration: 13200 nM
Compound 3: middle estimate off by 1.2-fold (0.08 log units), on the low side; the range from low to high includes it.
By their numbers in this assay, from the lowest: compounds 1 and 3 (each within the scatter of the next); then compound 2.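

In this assay, among the compounds shown here, placing nitro in place of hydrogen on the aromatic carbon ortho to the fluoro group gives a 1.5-fold higher number from compound 1 to compound 3 (0.17 log units; within the scatter) and so provides the first direct reading of this change, which neither compound 1 nor compound 2 could supply. The step from 4-fluorophenyl to 4-fluoro-3-nitrophenyl adds three heavy atoms and two hydrogen-bond acceptors at this position, yet compound 1 and compound 3 cannot be told apart on this read-out. This position therefore accepts this one group with no measurable shift in either direction, although a single pair says nothing about other groups there, and nothing measured here accounts for the result.

The compounds shown leave open whether an amine or a methoxy group at this same aromatic carbon would also stay within the scatter, and whether nitro would behave the same way on another carbon of this ring. For the compounds shown here, they also cannot show what the ethyl ester contributes with the 4-fluoro-3-nitrophenyl group in place, since no compound here differs from compound 3 at that ester alone.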